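Halophenyl hydrazones: from compound 2 to compound 3

The source may hold more compounds than are shown below. What is called first, only, known or untested is meant among the compounds shown, and "the series" means these compounds.

Measured so far:
Compound 1 `CC1CC/C(=N\Nc2cccc(Br)c2)c2ncc(C(=O)O)c(=O)n21` — > 320 umol/kg
Compound 2 `CC1CC/C(=N\Nc2ccc(Br)cc2)c2ncc(C(=O)O)c(=O)n21` — > 1000 umol/kg

In a functional assay on the whole organism for inhibition, with Rattus norvegicus as the target (a higher number here means that more compound is needed for the effect, a lower number that less compound is needed), compound 1 gives > 320 umol/kg, which is a limit of the assay and not a number. In this assay compound 2 gives > 1000 umol/kg, again a limit rather than a number. Compound 2 thus sits at one of the two limits shown, the other value being a limit as well (the limit of > 1000 umol/kg in this assay, at which 1 of the 2 values shown sits; (the limit of > 320 umol/kg in this assay, at which 1 of the 2 values shown sits)). For the measured compounds named here, the single measured step, a step that the two limits leave unreadable from compound 1 to compound 2, is of unreadable size.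

Compound 3 `CC1CC/C(=N\Nc2ccccc2I)c2ncc(C(=O)O)c(=O)n21` differs from compound 2 by 2-iodophenyl in place of 4-bromophenyl on an amine nitrogen. The step from compound 1 to compound 2 is the only one that bears on this change, and its two limits leave no direction or size to read. The expectation for compound 3 is therefore a value close to the same limit, with a number no higher from compound 2 to compound 3 (the limit leaves the size open) expected to stay within the scatter. Compound 3 is estimated at 1000 umol/kg, in the range 300 umol/kg to 3000 umol/kg.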

Compound 3, dose for 50% inhibition: > 1000 umol/kg
Compound 3 was reported as a limit (the forecaster's own chance of this, stated with the estimate: 75%); the middle value sits exactly at the limit.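

For the compounds shown here, compound 1, compound 2 and compound 3 all stand at limits of the assay rather than at numbers, and no step among them can be read in this assay. The compounds shown leave open whether 3-bromophenyl, 4-bromophenyl and 2-iodophenyl differ at all in this assay.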